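Ring swap on the double-bonded chain carbon

A few compounds are considered here, and "the series" means these few. Any claim that something is new, unique, unknown or untested is made for them only; others in the source may bear on it.

Measured so far in a functional assay on MCF7 cells (Homo sapiens) for inhibition, read by XTT assay, with a stated time of 48 h; a lower number here means a stronger inhibitor, a higher number a weaker inhibitor:
compound 1 `COc1ccc(C(=O)/C(=C/c2ccccc2F)CCOC(C)=O)cc1` gives > 100000 nM, a limit of the assay.
compound 2 `COc1ccc(C(=O)/C(=C/c2ccc(Cl)cc2Cl)CCOC(C)=O)cc1` gives 83400 nM.
compound 3 `COc1ccc(C(=O)/C(=C/C2CCCCC2)CCOC(C)=O)cc1` gives > 100000 nM, a limit of the assay.

Compound 3 thus stands at the limit, not at a number; in this assay two of the three values sit there, as the limit of > 100000 nM in this assay, at which 2 of the 3 values shown sit, records. Compound 4 `COc1ccc(C(=O)/C(=C/c2ccccc2Cl)CCOC(C)=O)cc1` differs from compound 3 in one place: 2-chlorophenyl in place of cyclohexyl on a double-bonded chain carbon bound to a double-bonded chain carbon. Among the measured compounds shown here, the steps that bear on this change are the aryl-to-cyclohexyl swaps already measured. The step of an at least 1.1-fold higher number from compound 2 to compound 3 (0.07 log units; that floor lies within the scatter) is only a floor within the scatter, and the step that the two limits leave unreadable from compound 1 to compound 3 cannot be read at all; the step of an at least 1.1-fold lower number from compound 1 to compound 2 (0.07 log units; that floor lies within the scatter) between the two aryl compounds is likewise a floor within the scatter. Nothing here shows a readable step in either direction for putting an aryl ring back in. Compound 4 is therefore expected to sit at or close to the limit again, and the expected step that the limit leaves unreadable from compound 3 to compound 4 is none beyond the scatter. The estimate for compound 4 in this assay is 110000 nM, within 55000 nM to 250000 nM.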

Compound 4, half-maximal inhibitory concentration: > 100000 nM
Compound 4: no number, only a limit; the forecaster's own chance of this, stated with the estimate: 65%; the middle value is on the limit's open side.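

In this assay compound 4 stands at a limit of the assay and not at a number (> 100000 nM). Among the compounds shown here, of the new steps, only the one for hydrogen in place of chloro on an aromatic carbon can be read, and only as a floor within the scatter (an at least 1.1-fold higher number from compound 2 to compound 4 (0.07 log units; that floor lies within the scatter)); the steps from compound 3 to compound 4 and from compound 1 to compound 4 cannot be read. With 2-chlorophenyl on this double-bonded chain carbon, compound 2 remains the only one of the four that carries a number, and the series gathers at one end of the range: the limit of > 100000 nM in this assay, at which 3 of the 4 values shown sit.

Still open, as far as these compounds go, is whether any group on this carbon gives a step beyond the scatter, for instance a phenyl ring carrying an amine or a carboxylic acid, or a longer chain. The rest of the core of compound 1 is shared by all four compounds, so the values shown say nothing about changes there.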